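The source may hold more compounds than are shown below. What is called first, only, known or untested is meant among the compounds shown, and "the series" means these compounds.

Working notes on the series. Compound 1 `CCO[C@H]1C[C@@H](c2coc3ccc(C)cc3c2=O)N(c2ccccc2)O1` carries the smaller of the two cores; compound 2 `Cc1ccc2occ([C@@H]3[C@H]4C(=O)N(c5ccccc5)C(=O)[C@H]4ON3c3ccccc3)c(=O)c2c1` and compound 3 `O=C1[C@H]2[C@H](ON(c3ccccc3)[C@@H]2c2coc3ccc(Br)cc3c2=O)C(=O)N1c1ccccc1` share the larger one. The difference between the two cores is not broken down here.

In a functional assay on THP-1 cells (Homo sapiens) for inhibition, read by sulforhodamine B assay, with a stated time of 48 h (on this read-out higher numbers stand for weaker inhibition and lower numbers for stronger inhibition), compound 1 gives 41000 nM. Among the compounds with values here, compound 3 gives 22300 nM in this assay, and the gap between that number and the one for compound 1 lies within the scatter, so no order is drawn between the two. For compound 2 this assay reports a limit and no number, > 60000 nM.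

Within the data shown here, the one measured step on the larger core is bromo in place of methyl on an aromatic carbon. It gives an at least 2.6-fold lower number from compound 2 to compound 3 (0.42 log units; beyond the scatter). The starting point of that step is the limit of > 60000 nM in this assay, at which 1 of the 3 values shown sits, so its full size is not known and may be greater than stated.

Compound 4 `CCO[C@H]1C[C@@H](c2coc3ccc(Br)cc3c2=O)N(c2ccccc2)O1` is not yet measured. It stands to compound 1 as compound 3 stands to compound 2, by the same change at the same place: bromo in place of methyl on an aromatic carbon. A step of the same direction and at least similar size is expected on the smaller core, because an at least 2.6-fold lower number from compound 2 to compound 3 (0.42 log units; beyond the scatter) lies beyond the scatter. The number for compound 4 in this assay is expected to be about 16000 nM, with a range from 6000 nM to 40000 nM. That expectation means a step of a 2.6-fold lower number from compound 1 to compound 4 (0.41 log units; beyond the scatter), with the upper end of the range allowing that the change could fall short on the smaller core.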

Compound 4, half-maximal inhibitory concentration: > 60000 nM
Compound 4 gave a limit, no number; the forecaster's own chance of this, stated with the estimate: 3%; at least 3.7-fold (0.57 log units) between middle value and limit.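

On the core of compound 1, bromo in place of methyl on an aromatic carbon gives an at least 1.4-fold higher number from compound 1 to compound 4 (0.16 log units; that floor lies within the scatter) in this assay, so the lower number seen on the larger core does not reappear. The change therefore does not carry over from one core to the other with the same direction in this assay: the same change on two cores in this assay, an at least 2.6-fold lower number (0.42 log units; beyond the scatter) from compound 2 to compound 3 and an at least 1.4-fold higher number (0.16 log units; that floor lies within the scatter) from compound 1 to compound 4, at least 3.9-fold (0.59 log units) apart, beyond the scatter of two such steps. As far as these compounds go, this rests on one pair per core and gives no general rule for the series, and the full size of each step and of the gap between them stays unknown, since each step has a limit at one end: the limit of > 60000 nM in this assay, at which 2 of the 4 values shown sit.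

The compounds shown leave open whether another group on the same aromatic carbon, such as chloro, methoxy, an amine or a carboxylic acid, would give a number on the core of compound 1 rather than a limit, and whether such a group would act alike on both cores. They also leave open whether a longer chain in place of the ethoxy group on the core of compound 1 would change the outcome of the swap from methyl to bromo.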